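A few compounds are considered here, and "the series" means these few. Any claim that something is new, unique, unknown or untested is made for them only; others in the source may bear on it.

Compound 1 `N=C(N)NCCC[C@@H]1NC(=O)CNC(=O)C[C@@H](C(=O)O)NC(=O)[C@@H](c2ccccc2)NC(=O)CNC1=O`: 19 nM
Compound 2 `N=C(N)NCCC[C@@H]1NC(=O)CNC(=O)C[C@@H](C(=O)O)NC(=O)[C@@H](c2ccccc2)NC(=O)[C@@H](CCCCN)NC1=O`: 8.7 nM
Compound 3 `N=C(N)NCCC[C@@H]1NC(=O)CNC(=O)C[C@@H](C(=O)O)NC(=O)[C@@H](c2ccccc2)NC(=O)[C@H](Cc2ccc(O)cc2)NC1=O`: 39 nM

In an assay on a protein complex for binding affinity to integrin alpha-5/beta-1 (Homo sapiens), read by ELISA (a lower number here means a stronger inhibitor, a higher number a weaker inhibitor), compound 3 gives the highest number of the three, with compound 1 giving the nearest lower number and compound 2 the lowest. Within the data shown here, compound 4 `N=C(N)NCCC[C@@H]1NC(=O)CNC(=O)C[C@@H](C(=O)O)NC(=O)[C@@H](c2ccccc2)NC(=O)[C@@H](Cc2ccc(O)cc2)NC1=O` keeps every atom and bond of compound 3; the only change is this: the two compounds have the same atoms and bonds; at least one stereo element is drawn with a configuration in one of them and without one in the other: 1 of 5 stereo elements differ; a stereocentre at a saturated ring carbon is drawn S in compound 3 and R in compound 4. The two measured steps, a 2.2-fold lower number from compound 1 to compound 2 (0.34 log units; beyond the scatter) and a 2.1-fold higher number from compound 1 to compound 3 (0.31 log units; beyond the scatter), each add a group at a saturated ring carbon and leave configuration untouched, so neither bears directly on an inversion of a stereocentre. Among the measured compounds shown here, with no comparable step in hand, the expected change in this assay from compound 3 to compound 4 is a 2.0-fold lower number from compound 3 to compound 4 (0.29 log units; within the scatter), with wide uncertainty in either direction. Compound 4 is therefore estimated at 20 nM, within a range of 6 nM to 70 nM.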

Compound 4, half-maximal inhibitory concentration: 8.7 nM
Beside the measured number, compound 4's estimate is 2.3-fold (0.36 log units) above it, and the stated range covers the measured number.
By their numbers in this assay, from the lowest: compounds 2 and 4 (each within the scatter of the next); then compound 1; then compound 3.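

At this ring carbon, configuration alone moves the number: in this assay there is a 4.5-fold lower number from compound 3 to compound 4 (0.65 log units; beyond the scatter). With the 4-hydroxybenzyl group in the R configuration, adding it to the unsubstituted ring carbon now gives a 2.2-fold lower number from compound 1 to compound 4 (0.34 log units; beyond the scatter), the opposite direction to the S configuration, and swapping it against the 4-aminobutyl group gives no change at the digits printed from compound 2 to compound 4 (within the scatter). The basis for this reading lies in the two drawings: the fact that one of compounds 3 and 4 is drawn with a defined configuration and the other without, at the place where they differ

As far as these compounds go, whether inverting this carbon also shifts the number for the 4-aminobutyl group remains open. So does how a carboxylic acid side chain here would fare in either configuration.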